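A few compounds are considered here, and "the series" means these few. Any claim that something is new, unique, unknown or untested is made for them only; others in the source may bear on it.

Measured so far:
- compound 2, `Cc1cccc(-n2nncc2CN2C(=O)C3(C(C#N)=C(N)Oc4c(N)cc5nc6ccccc6nc5c43)c3ccccc32)c1`: 12300 nM
- compound 1, `N#CC1=C(N)Oc2c(c3nc4ccccc4nc3c3ccccc23)C12C(=O)N(Cc1cnnn1-c1ccc(Br)cc1)c1ccccc12`: 44300 nM

In a functional assay on A549 cells (Homo sapiens) for antiproliferative activity, read by MTT assay, with a stated time of 48 h (on this read-out lower numbers stand for stronger inhibition and higher numbers for weaker inhibition), compound 2 gives 12300 nM, the lowest of the two numbers recorded; compound 1 gives 44300 nM, and the gap between these two lies beyond the scatter. Among the compounds with values here, no single-point step between measured compounds exists in this set, and compound 1 differs from compound 2 in more than one place, so no step can be assigned to any one change.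

Compound 3, `N#CC1=C(N)Oc2c(N)cc3nc4ccccc4nc3c2C12C(=O)N(Cc1cnnn1-c1ccc(F)cc1)c1ccccc12`, is not yet measured. It differs from compound 2 only by the change (4-fluorophenyl in place of 3-methylphenyl on an aromatic nitrogen), that is, 4-fluorophenyl in place of 3-methylphenyl on an aromatic nitrogen. Within the data shown here, with no measured step for this kind of exchange, the expectation is a step of about the size of the scatter, direction uncertain, expressed as a 1.2-fold higher number from compound 2 to compound 3 (0.09 log units; within the scatter). Compound 3 is therefore estimated at 15000 nM, within a range from 5000 nM to 45000 nM.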

Compound 3, half-maximal inhibitory concentration: > 50000 nM
Compound 3 gave a limit, no number; the forecaster's own chance of this, stated with the estimate: 10%; at least 3.3-fold (0.52 log units) between middle value and limit.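

In this assay, within the data shown here, the first step that can be read at a single place is an at least 4.0-fold higher number from compound 2 to compound 3 (0.60 log units; beyond the scatter), so the group on this aromatic nitrogen of the triazole bears on the read-out, even though 3-methylphenyl and 4-fluorophenyl are equal in heavy atoms and each holds one aromatic ring of carbon only. The value of compound 3, > 50000 nM, is a limit and not a number. The step therefore has no upper end: the limit of > 50000 nM in this assay, at which 1 of the 3 values shown sits.

Plain phenyl at this place would help to separate the share of the leaving methyl from that of the entering fluorine, and these compounds cannot do so. Going by these compounds, how an aminophenyl or a carboxyphenyl group would read here also remains open.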